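The source may report more compounds than this note shows. Statements on the series, on what has been measured and on what is new or still open speak of the compounds shown alone.

The study concerns three compounds measured in an ADME assay on THP-1 cells (Homo sapiens) for inhibition, read by MTT assay, with a stated time of 72 h (a higher number here means a weaker inhibitor of growth, a lower number a stronger inhibitor of growth), and one that has not yet been measured. Compound 1 has the structure `Cc1ccc2oc(-c3cc4ccccc4s3)cc(=O)c2c1`, and in this assay compound 1 gives > 100 ug/mL, which is a limit of the assay and not a number. Compound 2, `Cc1cc2oc(-c3cc4ccccc4s3)cc(=O)c2cc1Cl`, carries a chloro group on its core; in this assay compound 2 gives > 100 ug/mL, again a limit. Compound 3 has the open-chain structure `Cc1ccc(O)c(C(=O)CC(=O)c2cc3ccccc3s2)c1`, and in this assay compound 3 gives > 100 ug/mL, also a limit. Compound 3 therefore stands where all three measured values sit, namely at the limit of > 100 ug/mL in this assay, at which 3 of the 3 values shown sit, and no numerical ordering among the three can be drawn.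

The compound still to be measured is compound 4, `O=C(CC(=O)c1cc(Br)ccc1O)c1cc2ccccc2s1`. It differs from compound 3 by bromo in place of methyl on an aromatic carbon. For the measured compounds named here, since no step between measured compounds is available, the expectation rests on the fact that every measured value sits at the limit. In this assay the expected step is a number no higher from compound 3 to compound 4 (the limit leaves the size open), which means no change beyond the scatter is expected. For compound 4 the estimate in this assay is 100 ug/mL, with a range from 40 ug/mL to 250 ug/mL, and it is expected that the assay will most likely again report only a limit.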

Compound 4, concentration for 50% growth inhibition: > 100 ug/mL
Compound 4: only a limit was reported; the forecaster's own chance of this, stated with the estimate: 75%; the middle value sits exactly at the limit.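

In this assay compound 4 gives > 100 ug/mL, which is a limit of the assay and not a number. Compound 3 also stands only at a limit, so no step can be read from compound 3 to compound 4. The compounds shown leave open whether bromo in place of methyl changes growth inhibition at all, with every value at one limit: the limit of > 100 ug/mL in this assay, at which 4 of the 4 values shown sit.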